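Weighing a smaller group on the shared core

The compounds below may be only part of what the source reports. "The series", "measured", "known", "first", "only" and "open" are said of these compounds alone.

compound 1 `COc1ccc(C)c(C2CN(Cc3ccc(F)cc3)c3nc(-c4c(C)noc4C)ncc32)c1`: "not determined" (no result reported)
compound 2 `CNc1cc(-c2ccc3cnn(Cc4cc(OC)cc(OC)c4)c3c2)cn(C)c1=O`: 190 nM
compound 3 `CCNc1cc(-c2ccc3cnn(Cc4cc(OC)cc(OC)c4)c3c2)cn(C)c1=O`: 2590 nM

Going by the values given here, in a functional assay on MV4-11 cells (Homo sapiens) for antiproliferative activity, read by luminescence and CellTiter-Glo, with a stated time of 72 h (on this read-out lower numbers stand for stronger inhibition and higher numbers for weaker inhibition), compound 2 gives 190 nM, the lower of the only two numbers available, since compound 1 has no reported result. The next compound to be tested is compound 4 `CNc1cc(-c2ccc3cnn(CC4CC4)c3c2)cn(C)c1=O`, which keeps the core of compound 2 but changes one group: cyclopropyl in place of 3,5-dimethoxyphenyl on a saturated chain carbon bound to an aromatic nitrogen. In plain terms, cyclopropyl stands in place of 3,5-dimethoxyphenyl on a saturated chain carbon bound to an aromatic nitrogen.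

Among the compounds with values here, the only measured step is a 14-fold higher number from compound 2 to compound 3 (1.13 log units; beyond the scatter), and it lies beyond the scatter. It comes from methyl in place of hydrogen on a saturated chain carbon bound to a nitrogen on an aromatic ring. Within the data shown here, that is a different place, and both compounds in that step still carry 3,5-dimethoxyphenyl, so no measured pair tests the present swap directly. The step offers only a loose guide to size: one added methyl moved the number a long way, so a much larger swap may well do the same. A higher number in this assay seems the likelier direction, though this remains uncertain.

The expected outcome is a 4.7-fold higher number from compound 2 to compound 4 (0.68 log units; beyond the scatter), an estimate with wide margins. For compound 4 the estimated value is 900 nM, with an expected range from 200 nM to 5000 nM.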

Compound 4, half-maximal inhibitory concentration: 3450 nM
Compound 4: the middle estimate sits 3.8-fold (0.58 log units) below what was measured; the measured number falls inside the stated range.
By their numbers in this assay, from the lowest: compound 2; then compounds 3 and 4 (each within the scatter of the next).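

In this assay, replacing 3,5-dimethoxyphenyl with cyclopropyl on a saturated chain carbon bound to an aromatic nitrogen gives an 18-fold higher number from compound 2 to compound 4 (1.26 log units; beyond the scatter), which is a large loss of activity. Going by these compounds alone, this is the first measured sign that this position matters as well, since the earlier step concerned only a change at a different place on the molecule. The swap replaces a group of 10 heavy atoms, including a six-membered aromatic ring and 2 hydrogen-bond acceptors, with one of 3 heavy atoms, a three-membered non-aromatic ring and 0 hydrogen-bond acceptors, but no measurement shown here explains the drop in activity.

Size, ring type and hydrogen-bond acceptors all change together in this single step, so the compounds shown cannot separate their contributions. From the compounds shown here alone, it remains open whether a plain phenyl group, which would keep an aromatic ring without the two methoxy groups, or a longer chain such as butyl, which would have no ring at all, would hold activity closer to that of compound 2.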